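The compounds below may be only part of what the source reports. "The series", "measured", "known", "first", "only" and "open" are said of these compounds alone.

Compound 1 `COc1ccc(C2=C(c3ccc(SC)cc3)CC3CCCN3C2=O)cc1O`: 5000 nM
Compound 2 `COc1ccc(C2=C(c3ccc(SC)cc3)CC3CCCN3C2=O)cc1OC(=O)CNC(=O)OC(C)(C)C`: 6000 nM
Compound 3 `COc1ccc(C2=C(c3ccc(SC)cc3)CC3CCCN3C2=O)cc1OC(=O)C1CCCN1C(=O)OC(C)(C)C`: 2000 nM

In a functional assay on U-251 cells (Homo sapiens) for cytotoxicity (on this read-out higher numbers stand for weaker inhibition of growth and lower numbers for stronger inhibition of growth), compound 2 reads 6000 nM. That puts it at the upper end of the three numbers, within the scatter of compound 1 and clearly above compound 3. Compound 4 `COc1ccc(C2=C(c3ccc(SC)cc3)CC3CCCN3C2=O)cc1C` has not been measured. It carries a methyl, ortho to a methoxy group, and differs from compound 2 as follows: one carbon atom in place of a group of 12 heavy atoms (7 carbon, 1 nitrogen, 4 oxygen; no ring), on an aromatic carbon. Two measured steps alter this same group: a 1.2-fold higher number from compound 1 to compound 2 (0.08 log units; within the scatter) and a 3.0-fold lower number from compound 2 to compound 3 (0.48 log units; beyond the scatter). Neither places a carbon there, so they guide the estimate only loosely. Both stayed small, so only a small change is expected: a 1.5-fold lower number from compound 2 to compound 4 (0.18 log units; within the scatter). Compound 4 is estimated at 4000 nM, with an expected range of 1500 nM to 10000 nM.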

Compound 4, concentration for 50% growth inhibition: 90 nM
For compound 4 the middle estimate is 44-fold (1.65 log units) above the measured one, and the stated range ends above it.
By their numbers in this assay, from the lowest: compound 4; then compound 3; then compounds 1 and 2 (each within the scatter of the next).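

In this assay, among these compounds, this position turns out to be far more sensitive than the earlier compounds suggested. Swapping the hydroxy for a methyl gives a 56-fold lower number from compound 1 to compound 4 (1.74 log units; beyond the scatter) and replacing the large ester group with that methyl gives a 67-fold lower number from compound 2 to compound 4 (1.82 log units; beyond the scatter) while the earlier steps here were small or modest, so a single carbon on this aromatic ring carbon can matter greatly. No measurement shown here accounts for this jump. Whether it is specific to methyl stays open, as the compounds shown do not reveal how an ethyl, a chlorine or an amine would read at this carbon.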